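Series notes: pyridyl swap on the amide carbonyl

The compounds below may be only part of what the source reports. "The series", "measured", "known", "first", "only" and "open" are said of these compounds alone.

Measured compounds:
compound 1 `O=C(Nc1cccc(S(=O)(=O)Nc2ccccc2)c1)c1ccc(Cl)cc1Cl`, in a functional assay on HEK293 cells for agonist activity at probable G-protein coupled receptor 27 (Homo sapiens), read by a luciferase reporter and beta-arrestin recruitment, with a stated time of 10 min (a lower number here means a smaller maximal response, a higher number a larger maximal response), compound 1 gives "not determined" (no result reported)
compound 2 `O=C(Nc1ccc(S(=O)(=O)Nc2ccccc2)cc1)c1ccc(Cl)cc1F`, 57%

Compound 2 carries the only number shown; the other entry gives no figure. In this assay compound 2 gives 57%. Compound 3 `O=C(Nc1ccc(S(=O)(=O)Nc2ccccc2)cc1)c1ccc(Cl)nc1F` is not yet measured. It differs from compound 2 in one place: 6-chloro-2-fluoropyridin-3-yl in place of 4-chloro-2-fluorophenyl on a carbonyl carbon. For the measured compounds named here, no step between measured compounds is available to set a scale, so the expected step of a number 7 percentage points lower from compound 2 to compound 3 (within the scatter) is set as none beyond the usual scatter. Compound 3 is therefore estimated at 50%, with a range from 25% to 75%.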

Compound 3, largest response reached (Emax), in percent of the reference or control that the assay uses: 78%
For compound 3 the middle estimate is 28 percentage points below the measured one, outside the stated range (above it).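

In this assay, the swap of 4-chloro-2-fluorophenyl for 6-chloro-2-fluoropyridin-3-yl on a carbonyl carbon gives a number 21 percentage points higher from compound 2 to compound 3 (beyond the scatter) and so is not a neutral exchange. This position accepts a ring nitrogen, and the maximal response rises with the same count of heavy atoms and one added hydrogen-bond acceptor. No available measurement bears on the reason for this step.

As far as these compounds go, whether an amine or a methoxy group in place of the chlorine on the pyridine ring would keep this response remains open. Potency is also open, since only the maximal response is shown.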